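Swapping an ester end for hydroxymethyl

The compounds below may be only part of what the source reports. "The series", "measured", "known", "first", "only" and "open" are said of these compounds alone.

Measured in a functional assay on the whole organism for inhibition, with Rattus norvegicus as the target, read by paw edema, with stated times of 1 h and 3 h; a lower number here means that less compound is needed, a higher number that more compound is needed for the effect:
compound 1 `C/C(=N\OCC(N)=O)c1ccc(Cl)cc1`: 24 mg/kg
compound 2 `CCOC(=O)CO/N=C(\C)c1ccc(Cl)cc1`: 32 mg/kg
compound 3 `CCCOC(=O)CO/N=C(\C)c1ccc(Cl)cc1`: 14 mg/kg

These three share a core and differ only in the group on the carbonyl. Compound 3 is clearly separated from only one of the others. The data show a 2.3-fold lower number from compound 2 to compound 3 (0.36 log units; beyond the scatter), but also a 1.7-fold lower number from compound 1 to compound 3 (0.23 log units; within the scatter). The remaining pair shows a 1.3-fold higher number from compound 1 to compound 2 (0.12 log units; within the scatter).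

Compound 4 `C/C(=N\OCCO)c1ccc(Cl)cc1` has hydroxymethyl in place of propoxycarbonyl on a saturated chain carbon bound to an oxygen on an unsaturated carbon. Here the carbonyl itself is gone, and no measured step removes it, so the three steps above are only indirect guides. All of them were small, so no large change is expected in this assay. A modest drift toward a higher number seems likelier than a further drop, though it should stay within the scatter. The expected result is a 1.7-fold higher number from compound 3 to compound 4 (0.23 log units; within the scatter). For compound 4 the estimated value is 24 mg/kg, with an expected range of 10 mg/kg to 60 mg/kg.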

Compound 4, dose for half-maximal effect: 29 mg/kg
The estimate for compound 4 lay 1.2-fold (0.08 log units) below the measured number; the range from low to high includes it.
By their numbers in this assay, from the lowest: compounds 3, 1, 4 and 2 (each within the scatter of the next, the first and the last beyond it).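

The carbonyl can be removed from this position without losing the effect altogether in this assay. Changing propoxycarbonyl to hydroxymethyl gives a 2.1-fold higher number from compound 3 to compound 4 (0.32 log units; beyond the scatter) and is a modest step, while the same change from ethoxycarbonyl gives a 1.1-fold lower number from compound 2 to compound 4 (0.04 log units; within the scatter) and the change from carbamoyl gives a 1.2-fold higher number from compound 1 to compound 4 (0.08 log units; within the scatter) so only the propoxycarbonyl group stands apart from hydroxymethyl here. No measurement is at hand that could explain this difference.

The compounds shown leave open how a carboxylic acid or an amine would read at this place, and whether a butoxycarbonyl group would extend the step seen from ethoxycarbonyl to propoxycarbonyl. They also leave open whether a methoxymethyl group would read like hydroxymethyl in this assay.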